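The compounds below may be only part of what the source reports. "The series", "measured", "known", "first", "only" and "open" are said of these compounds alone.

Working notes on the series. Within the data shown here, compound 2 `O=S(=O)(NC1CCN(S(=O)(=O)c2ccccc2)CC1)c1cc(S(=O)(=O)c2ccccc2)ccc1C(F)(F)F` is the more soluble of the two compounds measured so far: in a physicochemical assay for solubility (a higher number here means a more soluble compound, a lower number a less soluble compound), compound 2 gives 25000 nM, while compound 1 `O=C(c1ccc(C(F)(F)F)cc1)N1CCC(NS(=O)(=O)c2cc(S(=O)(=O)c3ccccc3)ccc2C(F)(F)F)CC1` gives 6300 nM. Among the measured compounds shown here, the one measured step, a 4.0-fold higher number from compound 1 to compound 2 (0.60 log units; beyond the scatter), exchanges one group on the ring amine nitrogen for another, both aromatic.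

Compound 3 `CC(C)(O)CCN1CCC(NS(=O)(=O)c2cc(S(=O)(=O)c3ccccc3)ccc2C(F)(F)F)CC1` is not yet measured. It differs from compound 2 as follows: 3-hydroxy-3-methylbutyl in place of phenylsulfonyl on an amine nitrogen in a ring. Here the same nitrogen is changed again, but the group that leaves carries the aromatic ring and the two acceptors counted, and the group that enters is an open chain with one donor and one acceptor. For the measured compounds named here, the step of a 4.0-fold higher number from compound 1 to compound 2 (0.60 log units; beyond the scatter) concerns the same position and is therefore the only relevant precedent, yet it does not match this exchange, so its size carries only loosely. Given that compound 2 already sits at the top with 25000 nM, and that the prior change at this nitrogen moved this assay by a 4.0-fold higher number from compound 1 to compound 2 (0.60 log units; beyond the scatter), a further modest rise is expected, a 2.4-fold higher number from compound 2 to compound 3 (0.38 log units; beyond the scatter), with wide uncertainty. Compound 3 is thus estimated at 60000 nM, in the range 15000 nM to 250000 nM.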

Compound 3, solubility: 50000 nM
Estimate against measurement, compound 3: 1.2-fold (0.08 log units) above; the measured number falls inside the stated range.
By their numbers in this assay, from the lowest: compound 1; then compounds 2 and 3 (each within the scatter of the next).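

In this assay, the exchange on the amine nitrogen in the ring gives a 2.0-fold higher number from compound 2 to compound 3 (0.30 log units; within the scatter) and so puts an open chain with no ring, 3-hydroxy-3-methylbutyl, level with phenylsulfonyl; an aromatic ring at this position is therefore not needed to reach the number of compound 2. The comparison with the (4-(trifluoromethyl)phenyl)carbonyl group gives a 7.9-fold higher number from compound 1 to compound 3 (0.90 log units; beyond the scatter) as the widest step among the three compounds, which leaves compound 1 alone at the low end, while the two sulfonyl- and chain-bearing compounds cannot be separated in this assay at this position. Nothing available bears on why these numbers fall as they do.

As far as these compounds go, whether a plain alkyl chain without the hydroxyl, a longer chain, an amine or a carboxylic acid on this nitrogen would stay level with compound 2 and compound 3 remains open. From the compounds shown here alone, all three compounds share the rest of the structure, so it is also open whether the steps at this nitrogen would hold the same size on a different core.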